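From a Sulfonamide to a Triazole on a Saturated Ring

The source may hold more compounds than are shown below. What is called first, only, known or untested is meant among the compounds shown, and "the series" means these compounds.

Compound 1, `COc1ccc(-c2c(C)nc3c(N4CC[C@@H](NC(=O)Nc5ccccc5)C4)cc(C)nn23)cc1OC`, gives > 95% in an ADME assay on microsomes from liver (Homo sapiens) for metabolic stability, read by LC-MS, with NADPH named in the record, with a stated time of 60 min, tested at 1 uM, in the absence of a further agent (on this read-out higher numbers stand for a more stable compound and lower numbers for a less stable compound), which is a limit of the assay and not a number.
Compound 2, `COc1ccc(-c2c(C)nc3c(N4CC[C@@H](NC(=O)OC5CCCCC5)C4)cc(C)nn23)cc1OC`, gives > 95% in this assay, again a limit.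
Compound 3, `COc1ccc(-c2c(C)nc3c(N4CC[C@@H](NS(=O)(=O)C5CC5)C4)cc(C)nn23)cc1OC`, gives > 95% in this assay, again a limit.

Compound 3 therefore stands at the ceiling of what this assay reports, and so do the other two compounds: the limit of > 95% in this assay, at which 3 of the 3 values shown sit. Because of that, the steps a step that the two limits leave unreadable from compound 1 to compound 3 and a step that the two limits leave unreadable from compound 2 to compound 3 cannot be read in size, and the same holds for a step that the two limits leave unreadable from compound 1 to compound 2. The next compound, compound 4, `COc1ccc(-c2c(C)nc3c(N4CC[C@@H](n5cc(-c6ccccc6)nn5)C4)cc(C)nn23)cc1OC`, changes the group on the saturated ring: 4-phenyl-1H-1,2,3-triazol-1-yl in place of (cyclopropylsulfonyl)amino on a saturated ring carbon. No measured step bears on this change in a readable way, so no size of step can be expected in this assay from the numbers shown; all that is known is that every measured compound sits at the limit. Compound 4 is therefore estimated at 88%, with a range from 60% to 99%. This estimate means a step of a number at least 7 percentage points lower from compound 3 to compound 4 (that floor lies within the scatter) is expected, most likely still within the scatter.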

Compound 4, percent of the compound remaining: "unstable" (no number reported)
The entry for compound 4 holds no number; no gap can be computed for the estimate.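

In this assay, for the compounds shown here, compound 4 gives "unstable" (no number reported), so no step from compound 3 to compound 4 can be read in size. The compounds shown leave open how large that drop in stability is, and whether 4-phenyl-1H-1,2,3-triazol-1-yl alone accounts for it.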